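One Extra Methyl on the Acid-Bearing Ring

A few compounds are considered here, and "the series" means these few. Any claim that something is new, unique, unknown or untested is made for them only; others in the source may bear on it.

Of the compounds shown here, three share one core, and only one of them has given a plain number so far. Compound 1 `Cc1c(OCCCCOc2ccc(C(=O)O)cc2)ccc(C(=O)CC2CCCC2)c1O` is the reference point. In an assay on HEK293 cells for positive allosteric modulation of metabotropic glutamate receptor 2 (Rattus norvegicus), read by thallium flux, with a stated time of 2.5 min (a lower number here means that less compound is needed, a higher number that more compound is needed for the effect), compound 1 gives 824 nM, the only definite value among the three results shown. Compound 2 `Cc1c(OCCCCOc2ccc(C(=O)O)cc2)ccc(C(=O)CC2CCCC2)c1C` is a close relative, and in this assay compound 2 gives "not determined" (no result reported). Compound 3 `Cc1c(OCCCCOc2ccc(C(=O)O)c(Cl)c2)ccc(C(=O)CC(C)C)c1C` is another relative. In this assay compound 3 reaches only a limit, > 10000 nM. That result is the limit of > 10000 nM in this assay, at which 1 of the 3 values shown sits. Among the measured compounds shown here, compound 1 and compound 3 differ in several places at once, so their two results show only that one gave a number and the other did not.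

Compound 4 `Cc1ccc(C(=O)O)cc1OCCCCOc1ccc(C(=O)CC2CCCC2)c(O)c1C` has not yet been measured. It differs from compound 1 in a single place: 5-carboxy-2-methylphenyl in place of 4-carboxyphenyl on an oxygen on a saturated carbon. For the measured compounds named here, no step between two measured compounds that differ in one place is available to guide the size of this effect, so the expectation rests on the change alone. The step from compound 1 to compound 4 in this assay is expected to be small, a 1.5-fold higher number from compound 1 to compound 4 (0.16 log units; within the scatter), most likely within the usual scatter or slightly toward more compound needed. Compound 4 is therefore estimated at 1200 nM, with a range from 400 nM to 4000 nM.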

Compound 4, half-maximal effective concentration: 1290 nM
Compound 4: the middle estimate sits 1.1-fold (0.03 log units) below what was measured; measured number inside the range.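

In this assay, among the compounds shown here, replacing 4-carboxyphenyl with 5-carboxy-2-methylphenyl on the oxygen gives a 1.6-fold higher number from compound 1 to compound 4 (0.19 log units; within the scatter), the first step here that can be read between two measured compounds differing in one place. This shows that the group on this oxygen can be altered without a result that can be told apart from that of compound 1, even though the swap does two things at once: it adds a methyl to the ring, and the number of the carboxy position in the group's name goes from 4 to 5. For the compounds shown here, nothing measured so far offers a reason for this outcome.

Going by these compounds alone, the single step cannot say what the methyl and the shifted carboxy group each contribute, since the two could have separate effects that happen to offset each other, or neither could matter much. It also leaves open how this ring would read with an ethyl or a methoxy group in place of the added methyl, or with a tetrazole in place of the carboxylic acid.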